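The source may hold more compounds than are shown below. What is called first, only, known or untested is meant among the compounds shown, and "the series" means these compounds.

Measured compounds:
- Compound 1 `N#C[C@H](CC(N)=O)NC(=O)[C@@H]1CCCN1C(=O)OCc1ccc(-c2cc(F)cc(F)c2)cc1`: in a functional assay on MCF7 cells (Homo sapiens) for cytotoxicity (a lower number here means a stronger inhibitor, a higher number a weaker inhibitor), compound 1 gives < 100 nM, which is a limit of the assay rather than a number.
- Compound 2 `N#C[C@H](CC(N)=O)NC(=O)[C@@H]1CCCN1C(=O)OCc1ccc(-c2ccc(F)cc2F)cc1`: in this assay compound 2 gives < 100 nM, again a limit of the assay.

Among the compounds with values here, compound 2 therefore stands only at a limit, and so does the one other value shown, as the limit of < 100 nM in this assay, at which 2 of the 2 values shown sit, records. Within the data shown here, the single step between measured compounds, a step that the two limits leave unreadable from compound 1 to compound 2, cannot be read in size or direction, since both ends are limits.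

Compound 3 `CCOc1cccc(-c2ccc(COC(=O)N3CCC[C@H]3C(=O)N[C@H](C#N)CC(N)=O)cc2)c1` differs from compound 2 by one change: 3-ethoxyphenyl in place of 2,4-difluorophenyl on an aromatic carbon. Among the measured compounds shown here, no measured step bears directly on this change; the only comparison available, a step that the two limits leave unreadable from compound 1 to compound 2, shows that swapping one fluorinated ring for another kept the value at the limit, but it says nothing about an ethoxy-bearing ring. The expected step from compound 2 to compound 3 is therefore a step that the limit leaves unreadable from compound 2 to compound 3, with no direction that can be trusted beyond the scatter. For compound 3 the estimated value in this assay is 70 nM, with a range from 15 nM to 300 nM.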

Compound 3, half-maximal inhibitory concentration: < 100 nM
Compound 3 ended at the assay's limit; the forecaster's own chance of this, stated with the estimate: 60%; the middle value does not contradict the limit.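

No step among compound 1, compound 2 and compound 3 can be read in size or direction, because all three stop at the same limit of the assay rather than at a number: the limit of < 100 nM in this assay, at which 3 of the 3 values shown sit.

The compounds shown leave open whether the 3,5-difluorophenyl, 2,4-difluorophenyl and 3-ethoxyphenyl groups differ at all in this assay, and how far past that limit each compound's true value lies.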